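This account rests on a few compounds, and the source may have more. Where it says the series, first, only, none or still open, it means among the compounds named here.

Compound 1 `O=C(O)C[C@@H](NC(=O)[C@@H]1CCN1S(=O)(=O)c1cc(Cl)cc(Cl)c1)c1ccc(OC2CC2)cc1`: in an assay on RPMI-8866 cells for inhibition of integrin alpha-4/beta-1 (Homo sapiens) (on this read-out lower numbers stand for stronger inhibition and higher numbers for weaker inhibition), compound 1 gives 0.31 nM.
Compound 2 `O=C(O)C[C@@H](NC(=O)[C@@H]1CCN1S(=O)(=O)c1cc(Cl)cc(Cl)c1)c1ccc(OC(F)F)cc1`: in this assay compound 2 gives 1.3 nM.

On the numbers shown, compound 2 holds the higher of the two values; its nearest neighbour is compound 1, and the gap between them is the single measured step, a 4.2-fold higher number from compound 1 to compound 2 (0.62 log units; beyond the scatter), which concerns only the group on the oxygen on the aromatic ring.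

Compound 3 `O=C(O)C[C@@H](NC(=O)[C@@H]1CCN1S(=O)(=O)c1cc(Cl)cc(Cl)c1)c1ccc(Cl)c(F)c1` has not yet been measured. It differs from compound 2 by 4-chloro-3-fluorophenyl in place of 4-(difluoromethoxy)phenyl on a saturated chain carbon bound to an amide-type nitrogen and a saturated chain carbon. Among the compounds with values here, no measured step bears directly on this exchange: the one step measured changes the substituent carried by that oxygen, not the ring-bearing group as a whole, and it was modest in size. Nothing therefore points to a large move in this assay in either direction, and the working expectation is a number close to that of compound 2, with a wider range to cover the lack of a comparable step. The step expected here is a 1.1-fold lower number from compound 2 to compound 3 (0.03 log units; within the scatter). The estimate for compound 3 in this assay is 1.2 nM, with a range from 0.35 nM to 4 nM.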

Compound 3, half-maximal inhibitory concentration: 11 nM
For compound 3 the middle estimate is 9.2-fold (0.96 log units) below the measured one, outside the stated range (above it).
By their numbers in this assay, from the lowest: compound 1; then compound 2; then compound 3.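

Working notes on the ring-bearing group, read in this assay: the earlier compounds varied only the group carried by the oxygen, whereas compound 3 changes the whole aryl group on the saturated chain carbon bound to an amide-type nitrogen and a saturated chain carbon. Putting 4-chloro-3-fluorophenyl in place of 4-(difluoromethoxy)phenyl gives an 8.5-fold higher number from compound 2 to compound 3 (0.93 log units; beyond the scatter) and putting it in place of 4-(cyclopropyloxy)phenyl gives a 35-fold higher number from compound 1 to compound 3 (1.55 log units; beyond the scatter) so this place in the shared core is sensitive to the exchange, and both oxygen-bearing aryl groups give lower numbers than the halogen-only one. No measurement at hand accounts for either step.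

The exchange removes the oxygen and its substituent and adds two halogens at once, so the compounds shown do not separate the contribution of each part. From the compounds shown here alone, how a 4-chlorophenyl, a 3-fluorophenyl or a 4-methoxyphenyl group would stand at this place remains open, as does whether a 4-(cyclopropyloxy)phenyl group carrying an added fluorine would keep the low number of compound 1 at 0.31 nM in this assay on this core.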